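A few compounds are considered here, and "the series" means these few. Any claim that something is new, unique, unknown or untested is made for them only; others in the source may bear on it.

Compound 1 `O=C(CSc1nc(-c2ccccc2)c(C(=O)O)c(=O)[nH]1)Nn1c(COc2ccc(Cl)cc2Cl)nc2ccccc2c1=O`: 64.9%
Compound 2 `O=C(CSc1nc(-c2ccc(Cl)cc2)c(C(=O)O)c(=O)[nH]1)Nn1c(COc2ccc(Cl)cc2Cl)nc2ccccc2c1=O`: 61.4%
Compound 3 `Cn1c(SCC(=O)Nn2c(COc3ccc(Cl)cc3Cl)nc3ccccc3c2=O)nc(-c2ccccc2)c(C#N)c1=O`: 59.7%

In a functional assay on the whole organism (strain albino) for inhibition, with Rattus norvegicus as the target, read by paw edema, with stated times of 1 h and 3 h, at a dose of 100 mg/kg by the oral route (on this read-out higher numbers stand for a stronger effect at the one dose given and lower numbers for a weaker effect), compound 1 gives 64.9%, compound 2 gives 61.4% and compound 3 gives 59.7%. Compound 2 differs from compound 1 in one place only, (chloro in place of hydrogen on an aromatic carbon), and this change gave a number 3.5 percentage points lower from compound 1 to compound 2 (within the scatter). Compound 3 is built on a different core; how the core of compound 3 differs from that of compound 1 is not broken down here, so its value can only be compared, not traced to one change. The unmeasured compound 4 `Cn1c(SCC(=O)Nn2c(COc3ccc(Cl)cc3Cl)nc3ccccc3c2=O)nc(-c2ccc(Cl)cc2)c(C#N)c1=O` differs from compound 3 by chloro in place of hydrogen on an aromatic carbon, the same change as that from compound 1 to compound 2, at a place described in the same words. Because a number 3.5 percentage points lower from compound 1 to compound 2 (within the scatter) stayed within the scatter, a step of similar size is expected from compound 3 to compound 4, namely a number 2.7 percentage points lower from compound 3 to compound 4 (within the scatter) in this assay. One measured example is a thin basis, and the new core may respond differently. Compound 4 is therefore expected to give about 57% in this assay, most likely between 46% and 67%.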

Compound 4, a percentage reported as inhibition, in the whole organism at one dose (the size of the read-out at that dose, not a potency): 73.7%
For compound 4 the middle estimate is 16.7 percentage points below the measured one; the measured number lies above the stated range.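

Changing phenyl to 4-chlorophenyl in this assay gave a number 14 percentage points higher from compound 3 to compound 4 (beyond the scatter), so on this core the added chloro goes with a clearly stronger effect at the one dose given. Going by these compounds alone, the earlier step therefore could not be carried over from one core to the other, since the same change behaved differently on the two cores: the same change on two cores in this assay, a number 3.5 percentage points lower (within the scatter) from compound 1 to compound 2 and a number 14 percentage points higher (beyond the scatter) from compound 3 to compound 4, 17.5 percentage points apart, beyond the scatter of two such steps This rests on only two pairs of compounds, and it does not show which feature of the cores is responsible, why the outcome differs, or how a third core would respond.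

The compounds shown leave open whether another group at the same place on the aromatic ring, such as fluoro, methoxy or an amine, would also act differently on the two cores. They also leave open whether the gain seen with compound 4 would hold at other doses, as a single dose gives the size of an effect and not a potency.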